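A Side Chain Returns to the Aromatic Nitrogen

The source may hold more compounds than are shown below. What is called first, only, known or untested is meant among the compounds shown, and "the series" means these compounds.

Of the compounds shown here, three that share one core have been tested in a functional assay on SH-SY5Y cells (Homo sapiens) for cytotoxicity, read by MTT assay, with a stated time of 72 h; on this read-out lower numbers stand for stronger inhibition and higher numbers for weaker inhibition. Compound 1 `CN1CCN(CCCCCCn2c3c(c4ccccc42)C(=O)c2c[n+]([O-])c4ccccc4c2C3=O)CC1` gives 920 nM, and compound 2 `CN1CCN(CCCCCn2c3c(c4ccccc42)C(=O)c2c[n+]([O-])c4ccccc4c2C3=O)CC1` gives 830 nM, the step of a 1.1-fold lower number from compound 1 to compound 2 (0.04 log units; within the scatter) being small. Compound 3 `O=C1c2c[n+]([O-])c3ccccc3c2C(=O)c2[nH]c3ccccc3c21` gives 1380 nM; this is the highest of the three numbers, yet its gaps to compound 1 and compound 2 both lie within the scatter, so no order among the three can be claimed. The step of a 1.7-fold higher number from compound 2 to compound 3 (0.22 log units; within the scatter) shows what removing a side chain from the aromatic nitrogen did.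

Compound 4 `O=C1c2c[n+]([O-])c3ccccc3c2C(=O)c2c1c1ccccc1n2CCCCN1CCCCC1` is the next compound. The change is 4-(piperidin-1-yl)butyl in place of hydrogen on an aromatic nitrogen. The step from compound 2 to compound 3 is the closest guide, since it moved in the opposite sense on the same nitrogen and stayed within the scatter. A small step in the other direction, a somewhat lower number, is therefore expected. Compound 4 is estimated at 750 nM, with a range from 350 nM to 1600 nM, which corresponds to an expected step of a 1.8-fold lower number from compound 3 to compound 4 (0.26 log units; within the scatter).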

Compound 4, half-maximal inhibitory concentration: 230 nM
Compound 4: the middle estimate sits 3.3-fold (0.51 log units) above what was measured; the whole stated range lies above it.
By their numbers in this assay, from the lowest: compound 4; then compounds 2, 1 and 3 (each within the scatter of the next).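

In this assay, a side chain on this aromatic nitrogen now makes a difference larger than the scatter: 4-(piperidin-1-yl)butyl in place of hydrogen gives a 6.0-fold lower number from compound 3 to compound 4 (0.78 log units; beyond the scatter), whereas the earlier step at this nitrogen stayed within the scatter. The identity of the side chain also matters, since the chain ending in piperidin-1-yl stands apart from both chains ending in 4-methylpiperazin-1-yl, with a 3.6-fold lower number from compound 2 to compound 4 (0.56 log units; beyond the scatter) and a 4.0-fold lower number from compound 1 to compound 4 (0.60 log units; beyond the scatter). Nothing in the available data explains these differences.

Compound 4 differs from compound 1 and compound 2 in both chain length and terminal ring, so the contribution of each remains unresolved. A butyl chain ending in 4-methylpiperazin-1-yl, or a pentyl chain ending in piperidin-1-yl, would separate the two, and a butyl chain ending in morpholin-4-yl would test the ring further.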